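The source may hold more compounds than are shown below. What is called first, only, known or untested is meant among the compounds shown, and "the series" means these compounds.

Measured in a functional assay on MCF7 cells (Homo sapiens) for antiproliferative activity, read by sulforhodamine B assay, with a stated time of 48 h; on this read-out higher numbers stand for weaker inhibition and lower numbers for stronger inhibition:
compound 1 `O=C(CCCCCCN1C(=O)/C(=N\O)c2ccccc21)NO`: 790 nM
compound 2 `O=C(CCCCCCN1C(=O)/C(=N\O)c2cc(Cl)ccc21)NO`: 680 nM
compound 3 `O=C(CCCCCCN1C(=O)/C(=N\O)c2cc(Br)ccc21)NO`: 1770 nM

Compound 3 gives the highest of these three numbers, while compound 1 lies within the scatter of compound 2. Compound 4 `O=C(CCCCCCN1C(=O)/C(=N\O)c2cc([N+](=O)[O-])ccc21)NO` has not yet been measured. It departs from compound 1 by a single change, a nitro in place of hydrogen on an aromatic carbon.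

The closest guides are the two other single replacements of a hydrogen on an aromatic carbon. Chloro gave a 1.2-fold lower number from compound 1 to compound 2 (0.07 log units; within the scatter), and bromo gave a 2.2-fold higher number from compound 1 to compound 3 (0.35 log units; beyond the scatter). The two groups also differ from each other, with a 2.6-fold higher number from compound 2 to compound 3 (0.42 log units; beyond the scatter). So one replacement left the number in place and the other raised it modestly. Neither says much about nitro, which has not been tested on this core, so only a small upward step is expected, and it may not clear the scatter. The expected change is a 1.3-fold higher number from compound 1 to compound 4 (0.10 log units; within the scatter). Compound 4 is therefore estimated at 1000 nM, with an expected range of 350 nM to 2800 nM.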

Compound 4, half-maximal inhibitory concentration: 1340 nM
The estimate for compound 4 lay 1.3-fold (0.13 log units) below the measured number; low and high end bracket the measured number.
By their numbers in this assay, from the lowest: compounds 2, 1, 4 and 3 (each within the scatter of the next, the first and the last beyond it).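

In this assay, nitro is the only replacement shown at this aromatic carbon that brings in more than one heavy atom, yet it cannot be told apart from hydrogen, with a 1.7-fold higher number from compound 1 to compound 4 (0.23 log units; within the scatter). It also cannot be told apart from either halogen, with a 1.3-fold lower number from compound 3 to compound 4 (0.12 log units; within the scatter) and a 2.0-fold higher number from compound 2 to compound 4 (0.29 log units; within the scatter), although compound 2 and compound 3 do differ from each other beyond the scatter. Going by these compounds alone, a larger group containing nitrogen and oxygen is therefore accepted at this position, and the only steps beyond the scatter remain those from compound 1 and compound 2 to compound 3.

Nothing available explains these numbers. On these data alone, whether an amine or a carboxylic acid at this carbon would stay in the same range, and whether nitro would give a similar number on another carbon of the aromatic ring, remains open.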